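A Nitro Group Gives Way to Amino

This account rests on a few compounds, and the source may have more. Where it says the series, first, only, none or still open, it means among the compounds named here.

In a functional assay on SGC-7901 cells (Homo sapiens) for antiproliferative activity, read by MTT assay, with a stated time of 72 h (a higher number here means a weaker inhibitor, a lower number a stronger inhibitor), compound 1 `COc1ccc(-c2c(-c3cc(OC)c(OC)c(OC)c3)ss/c2=N/O)cc1` gives > 100000 nM, which is a limit of the assay. Among the compounds with values here, compound 2 `COc1ccc(-c2c(-c3cc(OC)c(OC)c(OC)c3)ss/c2=N/O)cc1[N+](=O)[O-]` gives 6560 nM, the only actual number so far. Within the data shown here, the sole measured step, an at least 15-fold lower number from compound 1 to compound 2 (1.18 log units; beyond the scatter), is large and beyond the scatter, though it starts from that limit. Compound 3 `COc1ccc(-c2c(-c3cc(OC)c(OC)c(OC)c3)ss/c2=N/O)cc1N` carries amino in place of nitro on the same aromatic carbon (amino in place of nitro on an aromatic carbon). The step of an at least 15-fold lower number from compound 1 to compound 2 (1.18 log units; beyond the scatter) shows that this carbon can count, but it does not rank amino against nitro. The expected change is small, with an estimated 1.6-fold lower number from compound 2 to compound 3 (0.21 log units; within the scatter) in this assay and no firm direction. Compound 3 is expected at 4000 nM, with an estimated range from 400 nM to 40000 nM.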

Compound 3, half-maximal inhibitory concentration: 2910 nM
Beside the measured number, compound 3's estimate is 1.4-fold (0.14 log units) above it; measured number inside the range.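

In this assay, within the data shown here, amino in place of nitro gives a 2.3-fold lower number from compound 2 to compound 3 (0.35 log units; beyond the scatter) and so, for the first time, ranks two groups on this aromatic carbon by two actual numbers. Amino also stands clear of hydrogen on the same carbon, with an at least 34-fold lower number from compound 1 to compound 3 (1.53 log units; beyond the scatter) as the step. As far as these compounds go, the true size of that step stays unknown, as it starts from a limit: the limit of > 100000 nM in this assay, at which 1 of the 3 values shown sits. From the compounds shown here alone, whether a hydroxyl, an acetamide or a methyl group on this carbon would match amino remains open, as does how a primary amine compares with a dimethylamino group here.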